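Adding a Second Chloro to the Core of Compound 1

The source may report more compounds than this note shows. Statements on the series, on what has been measured and on what is new or still open speak of the compounds shown alone.

Of the compounds shown here, three have been measured in a functional assay on A498 cells (Homo sapiens) for cytotoxicity, read by sulforhodamine B assay, with a stated time of 48 h; on this read-out lower numbers stand for stronger inhibition of growth and higher numbers for weaker inhibition of growth. Compound 1 `ClCc1cccc(Cn2cnc3ncnc(Cl)c32)c1` gives 18200 nM. Compound 2 `ClCc1cccc(Cn2cnc3c(Cl)ncnc32)c1` gives 17400 nM, and compound 3 `ClCc1ccc(Cn2cnc3nc(Cl)nc(Cl)c32)cc1` gives 11200 nM; all three numbers lie within the scatter of one another, so compound 1 stands level with the other two rather than apart from them. Compound 4 `ClCc1cccc(Cn2cnc3nc(Cl)nc(Cl)c32)c1` has not yet been measured. It differs from compound 1 by chloro in place of hydrogen on an aromatic carbon. Going by the values given here, no measured pair shows this change on its own, so the size of the step in this assay is open. Compound 3 carries the same pair of chloro groups on the same core and gives 11200 nM, which guides the expectation. Compound 4 is expected to give 12000 nM, between 6000 nM and 25000 nM, a step of a 1.5-fold lower number from compound 1 to compound 4 (0.18 log units; within the scatter) expected to stay within the scatter.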

Compound 4, concentration for 50% growth inhibition: 1510 nM
Compound 4: the middle estimate sits 7.9-fold (0.90 log units) above what was measured; the whole stated range lies above it.
By their numbers in this assay, from the lowest: compound 4; then compounds 3, 2 and 1 (each within the scatter of the next).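

In this assay chloro in place of hydrogen on the aromatic carbon between two ring nitrogen atoms gives a 12-fold lower number from compound 1 to compound 4 (1.08 log units; beyond the scatter) and so marks this position as one where a single heavy atom changes the read-out widely. The earlier compounds shown here, all within the scatter of one another, showed no such step. Nothing measured here explains it. On these data alone, whether an amine or a methoxy group on this same carbon would give a similar step remains open, as does whether any atom other than chlorine can do so.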